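This account rests on a few compounds, and the source may have more. Where it says the series, first, only, none or still open, it means among the compounds named here.

Measured compounds:
- compound 1 `COc1cc(-c2nn(-c3cccc(NC(=O)c4ccc(Cl)c(C(F)(F)F)c4)c3)cc2-c2ccncc2)ccc1Cl`: > 32500 nM
- compound 2 `O=C(Nc1cccc(-n2cc(-c3ccncc3)c(-c3ccc(Cl)c(O)c3)n2)c1)Nc1cccc(C(F)(F)F)c1`: > 32500 nM
- compound 3 `O=C(Nc1cccc(-n2cc(-c3ccncc3)c(-c3ccc(Cl)c(O)c3)n2)c1)Nc1ccc(Cl)c(C(F)(F)F)c1`: 2930 nM

In a functional assay on MOLT-4 cells (Homo sapiens) for inhibition, read by sulforhodamine B assay, with a stated time of 48 h (on this read-out higher numbers stand for weaker inhibition of growth and lower numbers for stronger inhibition of growth), compound 1 gives no number, only a limit of > 32500 nM. This is the limit of > 32500 nM in this assay, at which 2 of the 3 values shown sit. Compound 2 likewise gives only a limit, > 32500 nM. Compound 3 gives a measured value of 2930 nM in this assay.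

The step to compound 4 `COc1cc(-c2nn(-c3cccc(NC(=O)Nc4ccc(Cl)c(Cl)c4)c3)cc2-c2ccncc2)ccc1Cl` is (3,4-dichlorophenyl)amino in place of 4-chloro-3-(trifluoromethyl)phenyl on a carbonyl carbon. For the measured compounds named here, no measured pair shows this exact change; the one measured step, an at least 11-fold lower number from compound 2 to compound 3 (1.04 log units; beyond the scatter), concerns a chloro in place of hydrogen on an aromatic carbon and shows that such a change on this side of the molecule can move the number far. Compound 4 carries a (3,4-dichlorophenyl)amino group on the carbonyl carbon, which brings it closer to the arrangement of compound 3 than compound 1 is. Since compound 1 sits at the limit, the number for compound 4 is expected to fall below it, a step of about an at least 5.4-fold lower number from compound 1 to compound 4 (0.73 log units; beyond the scatter) in this assay. Compound 4 is therefore estimated at 6000 nM, with a range from 1500 nM to 32500 nM.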

Compound 4, concentration for total growth inhibition: 4480 nM
The estimate for compound 4 lay 1.3-fold (0.13 log units) above the measured number, and the stated range covers the measured number.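

In this assay, the change on the carbonyl carbon gives an at least 7.2-fold lower number from compound 1 to compound 4 (0.86 log units; beyond the scatter), so growth inhibition at this position responds to replacing 4-chloro-3-(trifluoromethyl)phenyl with (3,4-dichlorophenyl)amino. The earlier measured step involved only a chloro in place of hydrogen, whereas this one exchanges the whole group on the carbonyl carbon. The true size of the step remains unknown, since compound 1 has only a limit: the limit of > 32500 nM in this assay, at which 2 of the 4 values shown sit.

The entering group differs in more than one way, with a nitrogen added and a second chlorine in place of trifluoromethyl, so the compounds shown cannot separate the contribution of each part. Also open, on these data alone, is how a small methyl group or a larger morpholine on the carbonyl carbon would read in this assay.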